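A few compounds are considered here, and "the series" means these few. Any claim that something is new, unique, unknown or untested is made for them only; others in the source may bear on it.

Compound 1 `COC(=O)c1ccc(C(=O)Nc2cccc3c2N(S(=O)(=O)c2ccc(OC)cc2)CC3)cc1`: 312 nM
Compound 2 `COc1ccc(S(=O)(=O)N2CCc3cccc(NC(=O)c4ccc(F)cc4)c32)cc1`: 45 nM

These two values come from a functional assay on MKN-45 cells (Homo sapiens) for cytotoxicity (on this read-out lower numbers stand for stronger inhibition and higher numbers for weaker inhibition), where compound 2 holds the lower number of the pair. Compound 3 `COc1ccc(S(=O)(=O)N2CCc3cccc(NS(=O)(=O)c4ccccc4)c32)cc1` has not yet been measured. It carries phenylsulfonyl in place of (4-fluorophenyl)carbonyl on a nitrogen on an aromatic ring.

Going by the values given here, only one measured step bears on this change, and only indirectly: a 6.9-fold lower number from compound 1 to compound 2 (0.84 log units; beyond the scatter). That step swapped methoxycarbonyl for fluoro on an aromatic carbon, and it shows that the number in this assay can move with a change in this part of the molecule. Among the compounds with values here, no measured compound has phenylsulfonyl at this nitrogen, so direction and size remain uncertain. A modest rise is expected, of about the size of that one step or smaller.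

The expected change is a 2.9-fold higher number from compound 2 to compound 3 (0.46 log units; beyond the scatter). Compound 3 is estimated at 130 nM, with an expected range of 28 nM to 600 nM.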

Compound 3, half-maximal inhibitory concentration: 562 nM
The estimate for compound 3 lay 4.3-fold (0.64 log units) below the measured number, within the range that was stated.
By their numbers in this assay, from the lowest: compound 2; then compounds 1 and 3 (each within the scatter of the next).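

In this assay, the change from (4-fluorophenyl)carbonyl to phenylsulfonyl on a nitrogen on an aromatic ring gives a 12-fold higher number from compound 2 to compound 3 (1.10 log units; beyond the scatter). The earlier step, a 6.9-fold lower number from compound 1 to compound 2 (0.84 log units; beyond the scatter), kept the carbonyl on this nitrogen and altered only a group on an aromatic carbon, whereas this result shows that replacing the whole group on the nitrogen also moves the number, here in the direction of weaker inhibition. Nothing measured on these compounds accounts for the rise.

The step replaces the carbonyl with a sulfonyl and removes the fluoro at once, and the compounds shown do not separate these two changes. On these data alone, a plain benzoyl or a (4-fluorophenyl)sulfonyl group on this nitrogen would bear on that question, and how a benzyl group there would compare also remains open.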